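This account rests on a few compounds, and the source may have more. Where it says the series, first, only, none or still open, it means among the compounds named here.

Measured so far, in an in vitro functional assay on HEK293-A cells for positive allosteric modulation of metabotropic glutamate receptor 5 (Homo sapiens), read by FLIPR and calcium flux; on this read-out lower numbers stand for an effect already at smaller amounts and higher numbers for an effect only at larger amounts of compound:
compound 1, `Cc1cccc(N2CC(c3nc(-c4cccc(Cl)c4)no3)CC2=O)c1`, gives > 10000 nM; this is a limit of the assay, not a number.
compound 2, `Cc1ccc(N2CC(c3nc(-c4cccc(C)c4)no3)CC2=O)cc1`, gives 1300 nM.
compound 3, `Cc1ccc(N2CC(c3nc(-c4cccc(F)c4)no3)CC2=O)cc1`, gives 1200 nM.

Where compound 3 stands: its value is the lowest of the two numbers in this assay, and its nearest neighbour is compound 2, which sits within the scatter of it. Compound 1 contributes only a limit of > 10000 nM in this assay, at which 1 of the 3 values shown sits, and offers no number to rank against.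

The step to the unmeasured compound 4, `Cc1ccc(N2CC(c3nc(-c4cccc(Cl)c4)no3)CC2=O)cc1`, is chloro in place of fluoro on an aromatic carbon. Compound 4 differs from compound 1 in two places, so the limit of compound 1 cannot be read as a step on the same aromatic carbon; only its two values can be set side by side, and they say nothing firm about a single change.

Among the compounds with values here, the one measured step that bears on this position is a 1.1-fold lower number from compound 2 to compound 3 (0.03 log units; within the scatter). The two groups methyl and fluoro thus gave numbers within the scatter of each other on this aromatic carbon. Chloro is a third small group at the same place, and no measured step on this aromatic carbon has yet moved the value beyond the scatter. The expectation is therefore a step of a 1.1-fold lower number from compound 3 to compound 4 (0.04 log units; within the scatter), that is, no change beyond the scatter, with wider uncertainty because compound 1 with its chloro group remains at the limit.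

Compound 4 is estimated at 1100 nM in this assay, between 400 nM and 3500 nM.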

Compound 4, half-maximal effective concentration: 630 nM
For compound 4 the middle estimate is 1.7-fold (0.24 log units) above the measured one; measured number inside the range.
By their numbers in this assay, from the lowest: compounds 4, 3 and 2 (each within the scatter of the next, the first and the last beyond it). At a limit, above all of these: compound 1.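

In this assay, within the data shown here, chloro is the first group on this aromatic carbon, meta to a large group, to separate from another: a 2.1-fold lower number from compound 2 to compound 4 (0.31 log units; beyond the scatter) is a modest step beyond the scatter, while a 1.9-fold lower number from compound 3 to compound 4 (0.28 log units; within the scatter) stays within it. Methyl and chloro therefore stand apart, and fluoro lies within the scatter of both, so these three groups give no clean ranking. The largest step lies outside this position: with 3-chlorophenyl held, 4-methylphenyl in place of 3-methylphenyl on an amide-type nitrogen in a ring gives an at least 15-fold lower number from compound 1 to compound 4 (1.20 log units; beyond the scatter) and rests on compound 1, whose value is a limit and not a number: the limit of > 10000 nM in this assay, at which 1 of the 4 values shown sits.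

As far as these compounds go, it remains open whether bromo, trifluoromethyl, methoxy, a nitrile or an amine on this aromatic carbon would carry the value further from that of compound 2 than chloro does. From the compounds shown here alone, it also remains open whether the large step between 3-methylphenyl and 4-methylphenyl on the nitrogen would recur with 3-fluorophenyl in place of 3-chlorophenyl.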